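Benzimidazole pairs: dimethylamino to diethylamino on a methylated core

The source may report more compounds than this note shows. Statements on the series, on what has been measured and on what is new or still open speak of the compounds shown alone.

The measured compounds:
compound 1, `CN(C)CCCn1c(N)c(-c2nc3ccccc3[nH]2)c2nc(C#N)c(C#N)nc21`, with 2390 nM;
compound 2, `CCN(CC)CCCn1c(N)c(-c2nc3ccccc3[nH]2)c2nc(C#N)c(C#N)nc21`, with 1820 nM;
compound 3, `CN(C)CCCn1c(N)c(-c2nc3ccccc3n2C)c2nc(C#N)c(C#N)nc21`, with 11300 nM.

All three were tested in a functional assay on HL60/MX2 cells (Homo sapiens) for antiproliferative activity, read by MTT assay, with a stated time of 48 h; on this read-out lower numbers stand for stronger inhibition and higher numbers for weaker inhibition. Compound 1 and compound 2 differ in one place: diethylamino in place of dimethylamino on a saturated chain carbon, three bonds along the chain from an aromatic nitrogen. That change moved the read-out by a 1.3-fold lower number from compound 1 to compound 2 (0.12 log units; within the scatter), so the two numbers cannot be told apart. Compound 3 carries a different core, and the difference between the two cores is methyl in place of hydrogen on an aromatic nitrogen; this step is recorded as a 4.7-fold higher number from compound 1 to compound 3 (0.67 log units; beyond the scatter), and compound 3 gives the highest number of the three.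

Compound 4, `CCN(CC)CCCn1c(N)c(-c2nc3ccccc3n2C)c2nc(C#N)c(C#N)nc21`, has not yet been measured. It differs from compound 3 as follows: diethylamino in place of dimethylamino on a saturated chain carbon, three bonds along the chain from an aromatic nitrogen. This is the same change that separates compound 1 from compound 2, made on the methylated core instead. Where compound 3 is concerned, the expectation rests on the single earlier instance of this change, in which a 1.3-fold lower number from compound 1 to compound 2 (0.12 log units; within the scatter) was seen between compound 1 and compound 2, a step that lies within the scatter. Compound 4 is therefore expected to sit close to compound 3, with a step of a 1.3-fold lower number from compound 3 to compound 4 (0.10 log units; within the scatter), and the estimated value for compound 4 is 9000 nM, expected to fall between 4000 nM and 25000 nM.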

Compound 4, half-maximal inhibitory concentration: 4470 nM
Beside the measured number, compound 4's estimate is 2.0-fold (0.30 log units) above it; measured number inside the range.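

In this assay, diethylamino in place of dimethylamino gave a 2.5-fold lower number from compound 3 to compound 4 (0.40 log units; beyond the scatter) on the methylated core, and this step does not differ measurably from the one seen on the core of compound 1: the same change on two cores in this assay, a 1.3-fold lower number (0.12 log units; within the scatter) from compound 1 to compound 2 and a 2.5-fold lower number (0.40 log units; beyond the scatter) from compound 3 to compound 4, 1.9-fold (0.28 log units) apart, within the scatter of two such steps Read the other way round the same square of compounds, methyl in place of hydrogen on an aromatic nitrogen gave a 2.5-fold higher number from compound 2 to compound 4 (0.39 log units; beyond the scatter) on the diethylamino side, and this again agrees with the step on the dimethylamino side: the same change on two cores in this assay, a 4.7-fold higher number (0.67 log units; beyond the scatter) from compound 1 to compound 3 and a 2.5-fold higher number (0.39 log units; beyond the scatter) from compound 2 to compound 4, 1.9-fold (0.28 log units) apart, within the scatter of two such steps So, across these four compounds, each change carries from one partner to the other with no difference that can be told from scatter, although the amine step lies within the scatter on one core and beyond it on the other; this does not show that the amine change acts more strongly on the methylated core, and a single pair of cores in one cell line cannot establish a general rule for the series.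

On these data alone, whether the step would hold for a dipropylamino group or for a longer chain than 3-(diethylamino)propyl remains open. As far as these compounds go, it is equally open how an ethyl group on the aromatic nitrogen would compare with methyl, and whether either step would carry over to other cell lines.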